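One Chloro Fewer: What Dose to Expect for Compound 4

The source may hold more compounds than are shown below. What is called first, only, known or untested is meant among the compounds shown, and "the series" means these compounds.

Of the compounds shown here, three have been measured. Compound 1 `COc1ccc(C23CCC(=O)N2CCCO3)cc1` and compound 2 `O=C1CCC2(c3ccc(F)cc3)OCCCN12` share one core, and in a functional assay on the whole organism with Mus musculus as the target, in the maximal electroshock model (on this read-out higher numbers stand for an effect only at larger amounts of compound and lower numbers for an effect already at smaller amounts), compound 1 gives 93.8 mg/kg while compound 2 gives 68.7 mg/kg; the one-place step between them, a 1.4-fold lower number from compound 1 to compound 2 (0.14 log units; within the scatter), lies within the scatter. Compound 3 `O=C(CCC(=O)c1ccc(Cl)c(Cl)c1)NCCCO` is built on a different framework, and in this assay compound 3 gives 450 mg/kg, the highest of the three numbers, standing beyond the scatter from both compound 1 and compound 2.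

Compound 4 `O=C(CCC(=O)c1ccc(Cl)cc1)NCCCO` differs from compound 3 in one place: hydrogen in place of chloro on an aromatic carbon. Among the measured compounds shown here, no measured pair shows what removing a chloro does; the only one-place step on record, a 1.4-fold lower number from compound 1 to compound 2 (0.14 log units; within the scatter), concerns another exchange on another core and did not move the number beyond the scatter. With nothing closer to lean on, the expectation for compound 4 is a step of a 1.1-fold higher number from compound 3 to compound 4 (0.05 log units; within the scatter), meaning no change beyond the usual scatter from compound 3. Compound 4 is therefore estimated at 500 mg/kg in this assay, with an expected range from 220 mg/kg to 1100 mg/kg.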

Compound 4, dose for half-maximal effect: > 300 mg/kg
Compound 4: a limit, no number; the forecaster's own chance of this, stated with the estimate: 20%; the middle value is on the limit's open side.
By their numbers in this assay, from the lowest: compounds 2 and 1 (each within the scatter of the next); then compound 3.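

In this assay compound 4 gives > 300 mg/kg, which is a limit and not a number. The step from compound 3 to compound 4 cannot be read, because the result for compound 4 rests on a limit: the limit of > 300 mg/kg in this assay, at which 1 of the 4 values shown sits.

The compounds shown leave open whether hydrogen in place of chloro on an aromatic carbon moves the dose for half-maximal effect at all, and if so, in which direction and how far.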